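The source may report more compounds than this note shows. Statements on the series, on what has been measured and on what is new or still open speak of the compounds shown alone.

Among the measured compounds shown here, in a functional assay on K562 cells (Homo sapiens), read by MTT assay, with a stated time of 72 h (on this read-out higher numbers stand for weaker inhibition and lower numbers for stronger inhibition), compound 1 (`C#Cc1cn([C@@H]2O[C@H](CO)[C@@H](O)[C@H]2O)c2ncnc(OC)c12`) gives 300 nM as the only actual number in this small set. Compound 2 (`O=c1[nH]cnc2c1c(-c1ccccc1)cn2[C@@H]1O[C@H](CO)[C@@H](O)[C@H]1O`) reads > 20000 nM as a limit of the assay and not a number. Compound 3 (`Nc1nc(N)c2c(-c3ccco3)cn([C@@H]3O[C@H](CO)[C@@H](O)[C@H]3O)c2n1`) reads > 20000 nM in this assay and this too is a limit and not a number. For the measured compounds named here, compound 3 therefore gives no exact position, and the series so far shows the limit of > 20000 nM in this assay, at which 2 of the 3 values shown sit, as its main feature.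

Compound 4 (`Nc1nc(N)c2c(-c3cc4ccccc4o3)cn([C@@H]3O[C@H](CO)[C@@H](O)[C@H]3O)c2n1`) keeps the core of compound 3 and has 1-benzofuran-2-yl in place of furan-2-yl on an aromatic carbon, with 1-benzofuran-2-yl in place of furan-2-yl on an aromatic carbon as the full computed difference. Going by the values given here, no measured pair in the set isolates a change of this kind, so the step in this assay has no direct precedent. The expectation rests on compound 3 at > 20000 nM as a limit and on nothing firmer. The expected step of a number no higher from compound 3 to compound 4 (the limit leaves the size open) is none beyond the scatter and has no expected direction, although some gain in inhibition cannot be excluded. Compound 4 is estimated at 20000 nM with an expected range from 6000 nM to 30000 nM and a report of only a limit is the likeliest outcome.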

Compound 4, half-maximal inhibitory concentration: 18600 nM
Compound 4: the middle estimate sits 1.1-fold (0.03 log units) above what was measured, within the range that was stated.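

In this assay, among the compounds shown here, compound 4 gives 18600 nM, which is the first actual number on the core of compound 3 and shows that this aromatic carbon, two ring bonds from the ring nitrogen, can carry a group of this size and still give a readable result. Compound 3 reads > 20000 nM, and this is a limit and not a number. Replacing furan-2-yl with 1-benzofuran-2-yl gives an at least 1.0-fold lower number from compound 3 to compound 4 (0.03 log units; that floor lies within the scatter), so the added six-membered aromatic ring of carbon only yields a measured value, but no gain that can be shown to lie beyond the scatter, and the limit remains a main feature of the series: the limit of > 20000 nM in this assay, at which 2 of the 4 values shown sit.

From the compounds shown here alone, the true position of compound 3 remains open, and with it the real size of the step, which could be negligible or considerably larger than its floor. Also open, going by these compounds, is how an amine, a carboxylic acid or a longer alkyl chain in place of 1-benzofuran-2-yl on this same aromatic carbon would read, and whether any of these would move the number clearly away from the limit.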